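The compounds below may be only part of what the source reports. "The series", "measured", "known", "first", "only" and "open" are said of these compounds alone.

Measured in a functional assay on HEL cells (Homo sapiens) for inhibition, read by MTT assay, with a stated time of 48 h; a lower number here means a stronger inhibitor, a higher number a weaker inhibitor:
- compound 1 `O=S(=O)(c1ccccc1)c1c(OCCCCCCO)no[n+]1[O-]`: 2160 nM
- compound 2 `O=C(CCCOc1no[n+]([O-])c1S(=O)(=O)c1ccccc1)NO`: 670 nM
- compound 3 `O=C(CCCCCCOc1no[n+]([O-])c1S(=O)(=O)c1ccccc1)NO`: 9330 nM

Among these three, compound 2 has the lowest number, 670 nM, and its gaps to compound 1 and compound 3 both lie beyond the scatter. The next compound, compound 4 `O=C(COCCOc1no[n+]([O-])c1S(=O)(=O)c1ccccc1)NO`, has not yet been measured in this assay. It departs from compound 2 as follows: (hydroxycarbamoyl)methoxy in place of (hydroxycarbamoyl)methyl on a saturated chain carbon, two bonds along the chain from an oxygen on an aromatic ring. In words, (hydroxycarbamoyl)methoxy stands in place of (hydroxycarbamoyl)methyl on a saturated chain carbon, two bonds along the chain from an oxygen on an aromatic ring.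

Within the data shown here, no measured step makes this exact change, so the evidence is indirect. The closest is the chain extension, a 14-fold higher number from compound 2 to compound 3 (1.14 log units; beyond the scatter), a large step. The steps of a 3.2-fold lower number from compound 1 to compound 2 (0.51 log units; beyond the scatter) and a 4.3-fold higher number from compound 1 to compound 3 (0.64 log units; beyond the scatter) are both modest, and they show that the number moves in either direction as the chain end and length change. The chain of compound 4 is longer than that of compound 2 but shorter than that of compound 3, so a modest rise is expected, smaller than the step to compound 3. The expected step is a 2.2-fold higher number from compound 2 to compound 4 (0.35 log units; beyond the scatter). For compound 4 the estimated value is 1500 nM, with an expected range from 450 nM to 5000 nM.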

Compound 4, half-maximal inhibitory concentration: 6790 nM
Compound 4: the middle estimate sits 4.5-fold (0.66 log units) below what was measured; measured number above the stated range.
By their numbers in this assay, from the lowest: compound 2; then compound 1; then compounds 4 and 3 (each within the scatter of the next).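

In this assay, the (hydroxycarbamoyl)methoxy group in place of (hydroxycarbamoyl)methyl gives a 10-fold higher number from compound 2 to compound 4 (1.01 log units; beyond the scatter), so at this saturated chain carbon a change that keeps the hydroxycarbamoyl end and adds a chain oxygen costs a large part of what compound 2 has gained. Among these compounds, compound 4 cannot be told apart from the all-carbon chain of compound 3, with a 1.4-fold lower number from compound 3 to compound 4 (0.14 log units; within the scatter), and it also stands on the weaker side of the hydroxy-ended compound 1, with a 3.1-fold higher number from compound 1 to compound 4 (0.50 log units; beyond the scatter), which leaves compound 2 as the only hydroxycarbamoyl compound here with a lower number than compound 1. Nothing available here bears on why the number changes in this way.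

The compounds shown leave open whether the chain length or the chain oxygen accounts for the step from compound 2, a question that an all-carbon chain matching the length of the chain in compound 4 would settle. They also leave open whether a carboxylic acid or a primary amide at the end of the chain of compound 2 would hold its number.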